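The source may report more compounds than this note shows. Statements on the series, on what has been measured and on what is new or still open speak of the compounds shown alone.

Measured compounds:
- compound 1 `CCC(C(=O)N1CCN(c2cccc(C(F)(F)F)c2)CC1)N1C(=O)CC(C)C1=O` gives 30.3 mg/kg
- compound 2 `CCC(C(=O)N1CCN(c2cccc(Cl)c2)CC1)N1C(=O)CC(C)C1=O` gives 43.5 mg/kg
- compound 3 `CC(C(=O)N1CCN(c2ccccc2)CC1)N1C(=O)CC(C)(C)C1=O` gives "not determined" (no result reported)

In a functional assay on the whole organism (strain Swiss) with Mus musculus as the target, with a stated time of 0.25 h (a lower number here means that less compound is needed, a higher number that more compound is needed for the effect), compound 1 gives 30.3 mg/kg, the lowest of the two numbers at hand. Among the compounds with values here, its nearest neighbour is compound 2, and the only step computed between measured compounds, a 1.4-fold higher number from compound 1 to compound 2 (0.16 log units; within the scatter), lies within the usual scatter, so the two compounds cannot be ordered on these data. Compound 3 carries a methyl instead of an ethyl on the chain and two methyls on the ring, but no result was reported for it in this assay, so it offers no guidance on the change at issue.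

Compound 4 `CC1CC(=O)N(C(C)C(=O)N2CCN(c3cccc(C(F)(F)F)c3)CC2)C1=O` differs from compound 1 by hydrogen in place of methyl on a saturated chain carbon, two bonds along the chain from an amide-type nitrogen in a ring and a carbonyl carbon. Within the data shown here, none of the measured steps touches this position: the one step on record concerns the aromatic substituent, not the chain. The expectation for compound 4 therefore rests on compound 1 alone, with a wide range and no direction claimed beyond the scatter. The estimated step of a 1.2-fold higher number from compound 1 to compound 4 (0.06 log units; within the scatter) is expected to stay within the scatter. Compound 4 is thus estimated at 35 mg/kg, with a range from 15 mg/kg to 85 mg/kg.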

Compound 4, dose for half-maximal effect: 24.6 mg/kg
Compound 4: middle estimate off by 1.4-fold (0.15 log units), on the high side, and the stated range covers the measured number.
By their numbers in this assay, from the lowest: compounds 4, 1 and 2 (each within the scatter of the next).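

Before this result, the only measured step concerned the aromatic substituent, so nothing had been read at the chain carbon itself. In this assay, hydrogen in place of methyl on a saturated chain carbon, two bonds along the chain from an amide-type nitrogen in a ring and a carbonyl carbon, gives a 1.2-fold lower number from compound 1 to compound 4 (0.09 log units; within the scatter), so going from ethyl to methyl at this place cannot be told apart from repeated measurement, and compound 1 and compound 4 cannot be ordered. The data at hand offer no explanation for this outcome, whichever way it is read.

The compounds shown cover only ethyl and methyl at this place, so they leave open whether a longer chain such as propyl, a branched isopropyl, a phenyl ring, or a chain ending in an amine or a carboxylic acid would stay equally close to compound 1. They also leave open whether the same change reads alike with chloro on the aromatic ring, as the step at this carbon has been read only with trifluoromethyl there.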